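Chloro addition on the benzimidazole-aminophenol series

The source may hold more compounds than are shown below. What is called first, only, known or untested is meant among the compounds shown, and "the series" means these compounds.

Measured so far in an ADME assay on CHO cells (Cricetulus griseus) for inhibition, read by MTT assay; on this read-out lower numbers stand for stronger inhibition and higher numbers for weaker inhibition:
compound 1 `CCN(CC)Cc1cccc(Nc2nc3ccccc3[nH]2)c1O`: > 50000 nM (a limit of the assay)
compound 2 `CCNCc1cc(Cl)cc(Nc2nc3ccccc3n2Cc2ccc(C(F)(F)F)cc2)c1O`: 33800 nM
compound 3 `CCN(CC)Cc1cccc(Nc2nc3ccccc3n2Cc2ccc(C(F)(F)F)cc2)c1O`: > 50000 nM (a limit of the assay)

Compound 3 stands at the limit of this assay, as recorded in the limit of > 50000 nM in this assay, at which 2 of the 3 values shown sit. Among the measured compounds shown here, the only step recorded, a step that the two limits leave unreadable from compound 1 to compound 3, cannot be read, since both ends are limits. Compound 4 `CCN(CC)Cc1cc(Cl)cc(Nc2nc3ccccc3n2Cc2ccc(C(F)(F)F)cc2)c1O` differs from compound 3 by chloro in place of hydrogen on an aromatic carbon. For the measured compounds named here, no measured step isolates this change; compound 2, which also carries the chloro group, is the only compound with a number, and it sits close to the limit. Compound 4 is therefore expected to be weak in this assay, with an at least 1.1-fold lower number from compound 3 to compound 4 (0.04 log units; that floor lies within the scatter) not readable against the limit of compound 3. The estimate for compound 4 is 45000 nM, within 15000 nM to 150000 nM.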

Compound 4, half-maximal inhibitory concentration: > 50000 nM
Compound 4 ended at the assay's limit; the forecaster's own chance of this, stated with the estimate: 50%; middle value at least 1.1-fold (0.04 log units) away from the limit.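

In this assay compound 4 gives > 50000 nM, which is a limit of the assay. With the (diethylamino)methyl group in place, chloro para to the hydroxy group brings no number into range, and every step with limits at both ends cannot be read: the limit of > 50000 nM in this assay, at which 3 of the 4 values shown sit.
With chloro held fixed, ethyl in place of hydrogen on the amine nitrogen gives an at least 1.4-fold higher number from compound 2 to compound 4 (0.17 log units; that floor lies within the scatter).

From the compounds shown here alone, how far the compounds at the limit lie from a measurable number remains open. Also open, going by these compounds, is what a methoxy group or a nitrile would give at the chloro position.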